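The source may report more compounds than this note shows. Statements on the series, on what has been measured and on what is new or still open speak of the compounds shown alone.

Measured in a functional assay on A2780cisR cells (Homo sapiens) for cytotoxicity, read by MTT assay, with a stated time of 72 h; a higher number here means a weaker inhibitor, a lower number a stronger inhibitor:
- compound 1 `CC(C)(C(=O)NC1CCCCC1)N(CCCCCC(=O)NO)C(=O)c1ccccc1`: 281000 nM
- compound 2 `CN(C)c1ccc(C(=O)N(CCCCCC(=O)NO)C(C)(C)C(=O)NC2CCCCC2)cc1`: 107000 nM

Compound 1 holds the higher of the two numbers in this assay. Compound 3 `CC(C)(C)NC(=O)C(C)(C)N(CCCCCC(=O)NO)C(=O)c1ccccc1` departs from it by tert-butyl in place of cyclohexyl on an amide-type nitrogen. Among the measured compounds shown here, the only measured step, a 2.6-fold lower number from compound 1 to compound 2 (0.42 log units; beyond the scatter), is modest and concerns an aromatic carbon, so it bears on this change only loosely. For the measured compounds named here, no measured step touches the amide-type nitrogen, and the data give no direction, so no step beyond the scatter is expected. The estimate amounts to an expected 1.1-fold higher number from compound 1 to compound 3 (0.03 log units; within the scatter). For compound 3 the expected value is 300000 nM, with an estimated range of 130000 nM to 700000 nM.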

Compound 3, half-maximal inhibitory concentration: 579000 nM
Compound 3: the middle estimate sits 1.9-fold (0.29 log units) below what was measured; measured number inside the range.
By their numbers in this assay, from the lowest: compound 2; then compound 1; then compound 3.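

Putting tert-butyl in place of cyclohexyl on the amide-type nitrogen gives a 2.1-fold higher number from compound 1 to compound 3 (0.31 log units; beyond the scatter) in this assay, which shows that this position, untouched by the earlier step, responds to a change of group. The change removes the six-membered ring and also alters the heavy-atom count, and this single pair cannot separate those two differences. No available evidence accounts for the step.

As far as these compounds go, how a phenyl ring, a methyl group or a straight hexyl chain on this nitrogen would read remains open. So does whether the same change would give a similar step in the dimethylamino series of compound 2.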